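The source may hold more compounds than are shown below. What is called first, only, known or untested is meant among the compounds shown, and "the series" means these compounds.

Compound 1 `COc1ccc(/C=C/C(=O)/C=C/c2nc3cc(C)ccc3n2C)cc1O` gives 3600 nM
Compound 2 `COc1ccc(/C=C/C(=O)/C=C/c2nc3cc([N+](=O)[O-])ccc3n2C)cc1O` gives 4800 nM

In a functional assay on MCF7 cells (Homo sapiens) for cytotoxicity, read by MTT assay, with a stated time of 48 h (a lower number here means a stronger inhibitor, a higher number a weaker inhibitor), compound 2 stands at 4800 nM and lies within the scatter of compound 1, so these two numbers cannot be ranked. Compound 3 `COc1ccc(/C=C/C(=O)/C=C/c2nc3cc(O)ccc3n2C)cc1O` keeps the core of compound 2 but carries hydroxy in place of nitro on an aromatic carbon. Among the compounds with values here, only one measured step bears on this change. It put nitro in place of methyl on that same aromatic carbon, and it gave a 1.3-fold higher number from compound 1 to compound 2 (0.12 log units; within the scatter). Within the data shown here, no compound with hydroxy at this place has been measured yet, so the range has to stay wide. The expectation in this assay is therefore no step beyond the scatter, with an estimated 1.2-fold lower number from compound 2 to compound 3 (0.08 log units; within the scatter). For compound 3 the estimated value is 4000 nM, with an expected range from 1500 nM to 11000 nM.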

Compound 3, half-maximal inhibitory concentration: 1900 nM
Beside the measured number, compound 3's estimate is 2.1-fold (0.32 log units) above it; the measured number falls inside the stated range.
By their numbers in this assay, from the lowest: compounds 3, 1 and 2 (each within the scatter of the next, the first and the last beyond it).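

In this assay, hydroxy in place of nitro gives a 2.5-fold lower number from compound 2 to compound 3 (0.40 log units; beyond the scatter), so this aromatic carbon now shows a step that can be read, which the earlier change of methyl to nitro did not. Hydroxy in place of methyl gives a 1.9-fold lower number from compound 1 to compound 3 (0.28 log units; within the scatter), so these two groups cannot be ranked here, and only nitro and hydroxy separate, by a modest margin. Nothing measured here explains that difference.

From the compounds shown here alone, it remains open whether an amine, a methoxy group or a carboxylic acid on this same carbon would give a number close to that of hydroxy or of nitro. Going by these compounds, it is also open whether the step from nitro to hydroxy would keep its size if the shared core were changed elsewhere.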